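Swapping the Piperazine Substituent: Compound 3 Expected

The source may hold more compounds than are shown below. What is called first, only, known or untested is meant among the compounds shown, and "the series" means these compounds.

Measured so far:
compound 1 `CC1=C(C(C)C(=O)NCCN(C)C)c2cc(F)ccc2/C1=C\c1ccc([S+](C)[O-])cc1` with 12700 nM
compound 2 `CC1=C(C(C)C(=O)N2CCN(CCCN(C)C)CC2)c2cc(F)ccc2/C1=C\c1ccc([S+](C)[O-])cc1` with 32000 nM

In a functional assay on HT-29 cells (Homo sapiens) for inhibition, read by CellTiter-Glo, with a stated time of 72 h (a lower number here means that less compound is tolerated, a higher number that more compound is tolerated), compound 1 gives 12700 nM. Compound 2 gives 32000 nM, the highest of the two numbers, reached through a 2.5-fold higher number from compound 1 to compound 2 (0.40 log units; beyond the scatter). Compound 3 `CC1=C(C(C)C(=O)N2CCN(c3ccncc3)CC2)c2cc(F)ccc2/C1=C\c1ccc([S+](C)[O-])cc1` is not yet measured; it carries pyridin-4-yl in place of 3-(dimethylamino)propyl on an amine nitrogen in a ring. Going by the values given here, only the step from compound 1 to compound 2 bears on it, and that step altered the group on the carbonyl carbon, not the substituent on the ring nitrogen, so it offers little direct guidance. For compound 3 the expected step is a 1.3-fold lower number from compound 2 to compound 3 (0.11 log units; within the scatter), likely within the scatter. The estimate for compound 3 is 25000 nM, with a range from 8000 nM to 80000 nM.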

Compound 3, half-maximal cytotoxic concentration: 4990 nM
Compound 3: middle estimate off by 5.0-fold (0.70 log units), on the high side, outside the stated range (below it).
By their numbers in this assay, from the lowest: compound 3; then compound 1; then compound 2.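

In this assay, the group on the amine nitrogen in the ring matters on its own: pyridin-4-yl in place of 3-(dimethylamino)propyl, with the same count of heavy atoms, gives a 6.4-fold lower number from compound 2 to compound 3 (0.81 log units; beyond the scatter) at this position. The carbonyl substituent's effect also depends on what the ring carries, as 4-(pyridin-4-yl)piperazin-1-yl in place of (2-(dimethylamino)ethyl)amino gives a 2.5-fold lower number from compound 1 to compound 3 (0.41 log units; beyond the scatter) and so runs opposite to a 2.5-fold higher number from compound 1 to compound 2 (0.40 log units; beyond the scatter) for the other piperazine. No evidence is available to account for this shift.

Going by these compounds, whether the shift follows the aromatic ring or its ring nitrogen remains open, and a phenyl or pyridin-3-yl group on the same nitrogen would separate the two.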